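Acyl variation on the shared core, reading from three points

The source may hold more compounds than are shown below. What is called first, only, known or untested is meant among the compounds shown, and "the series" means these compounds.

Measured in an assay on membranes from HeLa cells for displacement of a labelled ligand from adenosine receptor A3 (Homo sapiens), read by scintillation counting, with a stated time of 180 min, tested at 1 uM; on this read-out higher numbers stand for more inhibition at the one concentration tested (going by the name of the read-out) and lower numbers for less inhibition:
compound 1, `CCCC(=O)C1=C(C)NC(=O)NC1c1ccco1`: 1%
compound 2, `CC1=C(C(=O)CC(C)C)C(c2ccco2)NC(=O)N1`: 31%
compound 3, `CC1=C(C(=O)SC(C)C)C(c2ccco2)NC(=O)N1`: 1%

Compound 3 sits with compound 1 at the floor of the three numbers, the two together the lowest; the pair shows no change at the digits printed from compound 1 to compound 3 (within the scatter). Among the measured compounds shown here, compound 2 is the only member clearly apart, and the pair shows a number 30 percentage points lower from compound 2 to compound 3 (beyond the scatter).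

Compound 4, `CC1=C(C(=O)OCC2CC2)C(c2ccco2)NC(=O)N1`, is the next point. It differs from compound 3 by cyclopropylmethoxy in place of isopropylsulfanyl on a carbonyl carbon. The two steps that touch the same carbonyl carbon bear on it: no change at the digits printed from compound 1 to compound 3 (within the scatter) and a number 30 percentage points lower from compound 2 to compound 3 (beyond the scatter). For the measured compounds named here, neither involves an oxygen-linked group, so the effect of cyclopropylmethoxy at this carbon has no direct precedent. With two of the three measured acyl variants at the floor and only the isobutyl ketone higher, compound 4 is expected to stay near the floor, and the expected step is a number 7 percentage points higher from compound 3 to compound 4 (within the scatter), not beyond the usual scatter. The estimate for compound 4 is 8%, with a range from 0% to 30%.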

Compound 4, a percentage reported as inhibition, at one concentration (the size of the read-out at that concentration, not a potency): 1%
For compound 4 the middle estimate is 7 percentage points above the measured one; measured number inside the range.
By their numbers in this assay, from the lowest: compounds 1, 3 and 4 (each within the scatter of the next); then compound 2.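

Cyclopropylmethoxy brings the first oxygen-linked group and the first ring to this carbonyl carbon, yet in this assay the swap for isopropylsulfanyl gives no change at the digits printed from compound 3 to compound 4 (within the scatter) and so does not separate the two groups. The comparison with the propyl ketone reads the same, with no change at the digits printed from compound 1 to compound 4 (within the scatter) as the step. Against the isobutyl ketone the step is a number 30 percentage points lower from compound 2 to compound 4 (beyond the scatter) and the gap matches the one seen for compound 3, leaving compound 2 as the only member clearly apart among the four.

Open, going by these compounds, is whether isopropoxy, an amine on this carbonyl carbon or a longer branched ketone chain such as isopentyl would move the number off the level shared by compounds 1, 3 and 4. Also open, on these data alone, is whether those three differ at all, as a reading at one concentration cannot separate them. No supporting data bear on why the isobutyl ketone alone stands apart.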